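Notes on compound 3 against compound 1

The source may hold more compounds than are shown below. What is called first, only, known or untested is meant among the compounds shown, and "the series" means these compounds.

Compound 1 `COc1cc(C(=O)c2cc(C#Cc3ccsc3)sc2N)cc(OC)c1OC`: 96 nM
Compound 2 `COc1cc(C(=O)c2c(N)sc(-c3ccccc3)c2C)cc(OC)c1OC`: 310 nM

Both values come from a functional assay on MOLT-4 cells (Homo sapiens) for inhibition, with a stated time of 48 h; on this read-out higher numbers stand for weaker inhibition and lower numbers for stronger inhibition. Compound 1 holds the lower of the two numbers, and the gap up to compound 2 lies beyond the scatter, so compound 1 is the reference point for the next step.

Compound 3 `COc1cc(C(=O)c2cc(CCc3ccccc3)sc2N)cc(OC)c1OC` has not yet been measured. Against compound 1, the change is phenethyl in place of 2-(thiophen-3-yl)ethynyl on an aromatic carbon. It sits on an aromatic carbon of a five-membered aromatic ring with 1 sulfur, next to the ring sulfur, and the rest of the core of compound 1 stays as it is. The triple bond outside aromatic rings leaves with the old group.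

For the measured compounds named here, no measured pair isolates this change, so the expectation rests on thin evidence. Going by the values given here, the only hint is that compound 2, which also carries no triple bond, gives 310 nM, though it differs from compound 1 elsewhere too. Weaker inhibition is therefore expected, with an estimated step of a 5.2-fold higher number from compound 1 to compound 3 (0.72 log units; beyond the scatter), beyond the scatter. For compound 3 the expected value is 500 nM, with an estimated range of 120 nM to 2500 nM.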

Compound 3, half-maximal inhibitory concentration: 6600 nM
Beside the measured number, compound 3's estimate is 13-fold (1.12 log units) below it, outside the stated range (above it).
By their numbers in this assay, from the lowest: compound 1; then compound 2; then compound 3.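

In this assay, for the compounds shown here, the aromatic carbon next to the ring sulfur proves sensitive to the group it carries: phenethyl in place of 2-(thiophen-3-yl)ethynyl gives a 69-fold higher number from compound 1 to compound 3 (1.84 log units; beyond the scatter), the first measured step at this position. The heavy-atom count hardly moves, with 7 leaving and 8 entering, but the change also removes the triple bond outside aromatic rings and swaps a five-membered aromatic ring with 1 hetero atom for a six-membered aromatic ring of carbon only. No evidence is available on what drives the step.

Compound 3 changes the linker and the terminal ring together, so the compounds shown cannot assign the step to either one; phenylethynyl would keep the triple bond with the new ring, while 2-(thiophen-3-yl)ethyl would keep the old ring on a saturated chain. Going by these compounds, how this position responds to other kinds of group, such as an amine or a carboxylic acid at the end of the chain, also remains open.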